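Hydroxy for Methylamino on Two Different Cores

The compounds below may be only part of what the source reports. "The series", "measured", "known", "first", "only" and "open" are said of these compounds alone.

Compound 1 `CNC(=O)/C=C/c1ccncc1-c1ccc2ccccc2c1` and compound 3 `CNC(=O)/C=C/c1ccncc1-c1ccc2[nH]ccc2c1` carry the same methylcarbamoyl-bearing chain on two cores; the difference between the two cores is not broken down here. In a functional assay on MCF7 cells (Homo sapiens) for inhibition, read by sulforhodamine B assay, with a stated time of 72 h (on this read-out lower numbers stand for stronger inhibition of growth and higher numbers for weaker inhibition of growth), compound 1 gives 9340 nM. For compound 3 this assay reports only a limit, > 10000 nM. Compound 2 `O=C(O)/C=C/c1ccncc1-c1ccc2ccccc2c1` differs from compound 1 by hydroxy in place of methylamino on a carbonyl carbon. For compound 2 this assay likewise reports a limit, > 10000 nM. The step of an at least 1.0-fold higher number from compound 1 to compound 2 (0.02 log units; that floor lies within the scatter) is therefore only a floor, and it reads that way because of the limit of > 10000 nM in this assay, at which 2 of the 3 values shown sit.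

Compound 4 `O=C(O)/C=C/c1ccncc1-c1ccc2[nH]ccc2c1` differs from compound 3 by hydroxy in place of methylamino on a carbonyl carbon, the same change at the same place as between compound 1 and compound 2. That earlier step, an at least 1.0-fold higher number from compound 1 to compound 2 (0.02 log units; that floor lies within the scatter), did not move the number below the limit, and compound 3 itself already sits at a limit, so no better result is expected for compound 4. Compound 4 is estimated at 25000 nM, within 10000 nM to 80000 nM. The expected step is a step that the limit leaves unreadable from compound 3 to compound 4, most likely reported again as a limit rather than a number.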

Compound 4, concentration for 50% growth inhibition: > 10000 nM
Compound 4 was reported as a limit; the forecaster's own chance of this, stated with the estimate: 90%; the middle value lies beyond the limit too.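

No step can be read from compound 3 to compound 4 because both are reported only as limits: the limit of > 10000 nM in this assay, at which 3 of the 4 values shown sit. The compounds shown leave open whether hydroxy in place of methylamino on a carbonyl carbon changes growth inhibition on either core.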